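The source may hold more compounds than are shown below. What is called first, only, known or untested is meant among the compounds shown, and "the series" means these compounds.

Of the compounds shown here, three sharing one core have been measured in a functional assay on RPMI-8226 cells (Homo sapiens) for inhibition, read by sulforhodamine B assay, with a stated time of 48 h; on this read-out higher numbers stand for weaker inhibition of growth and lower numbers for stronger inhibition of growth. Compound 1 `COc1cc(-c2nn(-c3cccc(NC(=O)c4cccc(C(F)(F)F)c4)c3)cc2-c2ccncc2)ccc1Cl` gives 26600 nM, compound 2 `COc1cc(-c2nn(-c3cccc(NC(=O)Nc4ccc(Cl)c(Cl)c4)c3)cc2-c2ccncc2)ccc1Cl` gives 3260 nM, and compound 3 `COc1cc(-c2nn(-c3cccc(NC(=O)Nc4cccc(C(F)(F)F)c4)c3)cc2-c2ccncc2)ccc1Cl` gives 3120 nM. Compound 3 holds the lowest of these numbers, though the step of a 1.0-fold lower number from compound 2 to compound 3 (0.02 log units; within the scatter) stays within the scatter, while an 8.5-fold lower number from compound 1 to compound 3 (0.93 log units; beyond the scatter) and an 8.2-fold lower number from compound 1 to compound 2 (0.91 log units; beyond the scatter) lie well beyond it. Compound 4 `COc1cc(-c2nn(-c3cccc(NC(=O)c4ccc(Cl)c(C(F)(F)F)c4)c3)cc2-c2ccncc2)ccc1Cl` differs from compound 3 by 4-chloro-3-(trifluoromethyl)phenyl in place of (3-(trifluoromethyl)phenyl)amino on a carbonyl carbon. This reverses the kind of change that produced an 8.5-fold lower number from compound 1 to compound 3 (0.93 log units; beyond the scatter), so a step of similar size in the opposite direction is expected, roughly a 7.1-fold higher number from compound 3 to compound 4 (0.85 log units; beyond the scatter). Compound 4 is therefore estimated at 22000 nM, with a likely range from 7000 nM to 70000 nM.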

Compound 4, concentration for total growth inhibition: > 32500 nM
Compound 4 was reported as a limit; the forecaster's own chance of this, stated with the estimate: 10%; middle value at least 1.4-fold (0.16 log units) away from the limit.
By their numbers in this assay, from the lowest: compounds 3 and 2 (each within the scatter of the next); then compound 1. At a limit, above all of these: compound 4.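

Compound 4 gives a limit, not a number: the limit of > 32500 nM in this assay, at which 1 of the 4 values shown sits. Removing the amino nitrogen from the group on the carbonyl carbon gives an at least 10-fold higher number from compound 3 to compound 4 (1.01 log units; beyond the scatter) and an at least 9.9-fold higher number from compound 2 to compound 4 (0.99 log units; beyond the scatter), so the link from compound 1 to the urea compounds now has a second example. The added chloro on an aromatic carbon gives an at least 1.2-fold higher number from compound 1 to compound 4 (0.08 log units; that floor lies within the scatter), and this floor cannot show whether chloro changes anything. Still open, as far as these compounds go, is how a urea carrying (4-chloro-3-(trifluoromethyl)phenyl)amino on the carbonyl carbon would read, which would separate this ring's effect from that of the nitrogen.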